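Sulfonyl side-chain exchange at the shared core

The compounds below may be only part of what the source reports. "The series", "measured", "known", "first", "only" and "open" are said of these compounds alone.

Compound 2 `Cn1c(-c2ccccc2C(F)(F)F)nnc1C12CCC(COc3ccc(S(C)(=O)=O)cc3)(CC1)CC2` carries a 4-(methylsulfonyl)phenoxy group on a saturated chain carbon bound to a saturated ring carbon. In an assay on CHO-K1 cells for inhibition of 11-beta-hydroxysteroid dehydrogenase type 2 (Homo sapiens), read by scintillation proximity assay (on this read-out higher numbers stand for weaker inhibition and lower numbers for stronger inhibition), compound 2 gives only a limit, > 4000 nM, and no number. Compound 1 `CC(C)S(=O)(=O)CCC12CCC(c3nnc(-c4ccccc4C(F)(F)F)n3C)(CC1)CC2` differs in the same place by an (isopropylsulfonyl)methyl group. In this assay compound 1 also gives only a limit, > 4000 nM. The step that the two limits leave unreadable from compound 1 to compound 2 cannot be read in size, since both values sit together at the limit described by the limit of > 4000 nM in this assay, at which 2 of the 2 values shown sit. Compound 3 `CCS(=O)(=O)CCCCC12CCC(c3nnc(-c4ccccc4C(F)(F)F)n3C)(CC1)CC2` is not yet measured. Its change from compound 2 is 3-(ethylsulfonyl)propyl in place of 4-(methylsulfonyl)phenoxy on a saturated chain carbon bound to a saturated ring carbon. Within the data shown here, no measured step bears on this change beyond the two limits already in hand. Compound 3 is expected to give an estimate of 6000 nM, ranging from 2000 nM to 30000 nM, most likely again reported only as a limit. The step expected from this is a step that the limit leaves unreadable from compound 2 to compound 3.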

Compound 3, half-maximal inhibitory concentration: > 4000 nM
Compound 3: a limit, no number (the forecaster's own chance of this, stated with the estimate: 85%); the middle value does not contradict the limit.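

No step among compound 1, compound 2 and compound 3 can be read in size, as all three values are limits and not numbers: the limit of > 4000 nM in this assay, at which 3 of the 3 values shown sit.

The compounds shown leave open whether any side chain on the shared core gives a number in this assay, and how these sulfonyl side chains rank.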